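Removing the Chloro Group from the Core of Compound 3

The compounds below may be only part of what the source reports. "The series", "measured", "known", "first", "only" and "open" are said of these compounds alone.

In a functional assay on SW-620 cells (Homo sapiens) for cytotoxicity, read by MTT assay, with a stated time of 72 h (a higher number here means a weaker inhibitor, a lower number a stronger inhibitor), the three measured compounds give:
compound 1, `C#CCn1cc(C(=O)NC(CC(=O)Nc2ccccc2)c2ccccc2)c(=O)c2cc(F)c(Cl)nc21`: 5700 nM
compound 2, `C#CCn1cc(C(=O)NC(CC(=O)Nc2ccccn2)c2ccccc2)c(=O)c2ccc(Cl)nc21`: 2900 nM
compound 3, `C#CCn1cc(C(=O)NC(CC(=O)Nc2ccccc2)c2ccccc2)c(=O)c2ccc(Cl)nc21`: 2900 nM

Compound 3 stands level with compound 2 at the digits shown, and the two together hold the lowest numbers of the three; the step of a 2.0-fold lower number from compound 1 to compound 3 (0.29 log units; within the scatter) lies within the scatter, so compound 1 is not separated from them either. Compound 4, `C#CCn1cc(C(=O)NC(CC(=O)Nc2ccccc2)c2ccccc2)c(=O)c2cccnc21`, differs from compound 3 by hydrogen in place of chloro on an aromatic carbon. For the measured compounds named here, the one measured step that bears on this is a 2.0-fold lower number from compound 1 to compound 3 (0.29 log units; within the scatter), also a halogen giving way to hydrogen on the core, and it stayed within the scatter. The step of no change at the digits printed from compound 2 to compound 3 (within the scatter) alters a group on an amide-type nitrogen and says nothing about the core. The step of a 1.2-fold higher number from compound 3 to compound 4 (0.08 log units; within the scatter) is therefore expected to be small, likely not beyond the scatter. Compound 4 is estimated at 3500 nM, with a range from 1500 nM to 9000 nM.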

Compound 4, half-maximal inhibitory concentration: > 10000 nM
Compound 4: only a limit was reported; the forecaster's own chance of this, stated with the estimate: 5%; middle value at least 2.8-fold (0.45 log units) from the limit.
By their numbers in this assay, from the lowest: compounds 2, 3 and 1 (each within the scatter of the next). At a limit, above all of these: compound 4.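

In this assay, hydrogen in place of chloro on this aromatic carbon, next to the ring nitrogen, gives an at least 3.4-fold higher number from compound 3 to compound 4 (0.53 log units; beyond the scatter), so this chloro group counts for activity against these cells. The earlier halogen step, a 2.0-fold lower number from compound 1 to compound 3 (0.29 log units; within the scatter), involved fluoro rather than chloro and stayed within the scatter, so the loss of a halogen from the core does not always matter. The result for compound 4 is a limit: the limit of > 10000 nM in this assay, at which 1 of the 4 values shown sits.

As far as these compounds go, it remains open whether a bromo, methyl or amine group at this position would match compound 3. From the compounds shown here alone, it also remains open whether the chloro group matters as much with the pyridin-2-yl group of compound 2.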